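The source may hold more compounds than are shown below. What is called first, only, known or untested is meant among the compounds shown, and "the series" means these compounds.

Measured so far in a functional assay on CHO cells for agonist activity at Alpha-1B adrenergic receptor (Homo sapiens), read by FLIPR and calcium flux; a lower number here means that less compound is needed, a higher number that more compound is needed for the effect:
compound 1, `Cn1ccc(-c2cccc3c2CCC3c2ncc[nH]2)n1`: > 10000 nM
compound 2, `Cc1c(OCC2=NCCN2)ccc(Cl)c1NS(C)(=O)=O`: > 10000 nM
compound 3, `CS(=O)(=O)Nc1cccc2c1CCCC2c1ncc[nH]1`: > 10000 nM; > 10000 nM; > 10000 nM (3 entries)

None of these results is a number. Compound 1 reaches only the limit of this assay, > 10000 nM. Compound 2 likewise returns a limit, > 10000 nM. Compound 3 was run repeatedly and gave a limit on each occasion, > 10000 nM; > 10000 nM; > 10000 nM (3 entries). So compound 1 stands nowhere in particular among the values shown: every entry is a limit, and the one thing tying the set together is the limit of > 10000 nM in this assay, at which 2 of the 3 values shown sit. No two of these compounds differ in a single place, so no measured step exists that could anchor a change.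

Compound 4, `CNC(=O)c1cccc2c1CCC2c1ncc[nH]1`, is the next compound and differs from compound 1 in one place: methylcarbamoyl in place of 1-methyl-1H-pyrazol-3-yl on an aromatic carbon. Among the measured compounds shown here, with no measured step to lean on, the expectation rests on the limits alone, and nothing among them points toward a gain in potency. The step expected in this assay is therefore none beyond the scatter, with compound 4 estimated to stay at or near the limit, an estimated step that the limit leaves unreadable from compound 1 to compound 4. Compound 4 is expected to give about 15000 nM, in a range from 3000 nM to 60000 nM.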

Compound 4, half-maximal effective concentration: > 10000 nM
Compound 4 gave a limit, no number; the forecaster's own chance of this, stated with the estimate: 75%; the middle value lies beyond the limit too.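

Compound 1 and compound 4 each return only a limit, so no step can be read for methylcarbamoyl in place of 1-methyl-1H-pyrazol-3-yl in this assay: the limit of > 10000 nM in this assay, at which 3 of the 4 values shown sit. The compounds shown leave open whether any group on this aromatic carbon of the shared core would give a measurable half-maximal effective concentration in this assay.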